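Changing the acid side chain of compound 2

This account rests on a few compounds, and the source may have more. Where it says the series, first, only, none or still open, it means among the compounds named here.

Measured in a functional assay on MCF7 cells (Homo sapiens) for antiproliferative activity, read by MTT assay, with a stated time of 24 h; a higher number here means a weaker inhibitor, a lower number a stronger inhibitor:
Compound 1 `CCn1c(C(=O)NCC(=O)OC)ccc1C(CC)(CC)c1ccc(OCS(=O)(=O)c2ccccc2)c(C)c1`: > 50000 nM
Compound 2 `CCn1c(C(=O)N[C@H](C(=O)O)C(C)C)ccc1C(CC)(CC)c1ccc(OCS(=O)(=O)c2ccccc2)c(C)c1`: 24500 nM

Compound 1 gives > 50000 nM, which is a limit of the assay and not a number. For the measured compounds named here, compound 2 gives 24500 nM, the only actual number so far. Compound 3 `CCn1c(C(=O)NCCC(=O)O)ccc1C(CC)(CC)c1ccc(OCS(=O)(=O)c2ccccc2)c(C)c1` carries 2-carboxyethyl in place of 1-carboxy-2-methylpropyl on an amide-type nitrogen. Going by the values given here, one measured step bears on this, as it also changes the group on that nitrogen: an at least 2.0-fold lower number from compound 1 to compound 2 (0.30 log units; that floor lies within the scatter). Among the compounds with values here, with only that step to go on, no change beyond the scatter is expected in this assay, in either direction. The expected step is a 1.2-fold higher number from compound 2 to compound 3 (0.09 log units; within the scatter). Compound 3 is expected at about 30000 nM, with an estimated range of 12000 nM to 60000 nM.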

Compound 3, half-maximal inhibitory concentration: > 50000 nM
Compound 3 gave a limit, no number; the forecaster's own chance of this, stated with the estimate: 35%; at least 1.6-fold (0.22 log units) between middle value and limit.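

In this assay, putting 2-carboxyethyl in place of 1-carboxy-2-methylpropyl on the amide-type nitrogen gives an at least 2.0-fold higher number from compound 2 to compound 3 (0.30 log units; that floor lies within the scatter). Compound 3 keeps a carboxylic acid yet gives only a limit of the assay, not a number, so an acid on this chain is not enough by itself to give a measurable value. The step from compound 1 to compound 3 cannot be read, and the true size of the new step stays hidden: the limit of > 50000 nM in this assay, at which 2 of the 3 values shown sit.

Still open, on these data alone, is whether the branching or the chain length matters more. An amine or a longer branched chain on this nitrogen could help separate the two.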